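Swapping chloro for methoxy on the hydrazone aryl ring

This account rests on a few compounds, and the source may have more. Where it says the series, first, only, none or still open, it means among the compounds named here.

Two hydrazide-hydrazones have been measured in a functional assay on the whole organism (strain Wistar) for inhibition, with Rattus norvegicus as the target, read by paw edema, with a stated time of 3 h, at a dose of 10 mg/kg by the intraperitoneal route; on this read-out higher numbers stand for more inhibition at the one dose given (going by the name of the read-out) and lower numbers for less inhibition. Compound 1 `COc1cccc(/C=N/NC(=O)c2cccnc2Nc2cccc(C(F)(F)F)c2)c1` carries a methoxy group and a trifluoromethyl-bearing aniline on its core; in this assay compound 1 gives 30.3%. Compound 2 `CNc1ncccc1C(=O)N/N=C/c1cccc(Cl)c1` carries a chloro group and a methylamino group on the same core; in this assay compound 2 gives 39.6%. The two numbers lie within the usual scatter of each other, so compound 2 cannot be set apart from compound 1 on this read-out, even though its number is the one closest to the top of the pair.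

Compound 3 `CNc1ncccc1C(=O)N/N=C/c1cccc(OC)c1` is compound 2 with one change: methoxy in place of chloro on an aromatic carbon. The rest of the molecule is unchanged. Since compound 1, which also carries methoxy, gives 30.3%, a step from compound 2 to compound 3 beyond the scatter is not expected; the estimated step of a number 6.6 percentage points lower from compound 2 to compound 3 (within the scatter) is small and, if anything, downward. Compound 3 is therefore expected to give about 33% in this assay, within a range from 18% to 48%.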

Compound 3, a percentage reported as inhibition, in the whole organism at one dose (the size of the read-out at that dose, not a potency): 49.5%
Estimate against measurement, compound 3: 16.5 percentage points below; the whole stated range lies below it.
By their numbers in this assay, from the lowest: compounds 1, 2 and 3 (each within the scatter of the next, the first and the last beyond it).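

In this assay, methoxy in place of chloro on an aromatic carbon, meta to a large group, gives a number 9.9 percentage points higher from compound 2 to compound 3 (within the scatter), so this assay does not tell the two groups apart at this position. Going by these compounds alone, with methoxy held in place on both compounds, methyl in place of 3-(trifluoromethyl)phenyl on a nitrogen on an aromatic ring gives a number 19.2 percentage points higher from compound 1 to compound 3 (beyond the scatter), a modest step beyond the scatter and the first comparison here in which a single change can be read as a difference. This places the clearest change in the set at the substituent on the nitrogen rather than at the chloro or methoxy position, although no data presented here explain the size of either step.

On these data alone, it remains open whether a hydroxyl or an amine at the same aromatic carbon would stand apart from chloro and methoxy, and what an ethyl group, a longer chain or an unsubstituted phenyl would give on the nitrogen. As far as these compounds go, it is also open whether the step on the nitrogen would hold with chloro on the aromatic ring, and, with each number taken at a single dose, how these compounds compare in potency.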